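A few compounds are considered here, and "the series" means these few. Any claim that something is new, unique, unknown or untested is made for them only; others in the source may bear on it.

Measured so far in a functional assay on T-24 cells (Homo sapiens) for cytotoxicity, read by CCK-8 assay, with a stated time of 24 h; on this read-out lower numbers stand for stronger inhibition and higher numbers for weaker inhibition:
Compound 1, `C/C(=C\c1cc(-c2ccc(C)cc2)co1)C(N)=O`: compound 1 gives > 50000 nM, which is a limit of the assay rather than a number.
Compound 2, `C/C(=C\c1cc(-c2ccc(F)cc2)cs1)C(N)=O`: compound 2 gives > 50000 nM, again a limit of the assay.
Compound 3, `C/C(=C\c1cccc(-c2ccc(C)cc2)c1)C(N)=O`: compound 3 gives 7650 nM.

Compound 2 thus stands at the edge of what this assay can report: only compound 3 returns a number, and the limit of > 50000 nM in this assay, at which 2 of the 3 values shown sit, marks where compound 2 sits together with compound 1. Within the data shown here, no pair of measured compounds differs in just one place, so there is no measured step to lean on.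

Compound 4, `C/C(=C\c1cc(-c2ccc([N+](=O)[O-])cc2)cs1)C(N)=O`, has not yet been tested. It differs from compound 2 by nitro in place of fluoro on an aromatic carbon. Among the measured compounds shown here, since compound 2 already sits at a limit and no measured step shows what such a change does in this assay, the expectation is no movement beyond the usual scatter, with a real chance that compound 4 also comes back as a limit. Compound 4 is therefore estimated at 45000 nM, within a range of 12000 nM to 150000 nM, which means an expected step of an at least 1.1-fold lower number from compound 2 to compound 4 (0.04 log units; that floor lies within the scatter).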

Compound 4, half-maximal inhibitory concentration: > 50000 nM
Compound 4: only a limit was reported (the forecaster's own chance of this, stated with the estimate: 60%); middle value at least 1.1-fold (0.04 log units) from the limit.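

In this assay compound 4 gives > 50000 nM as a limit of the assay and not as a number. Compound 2 also stands at a limit, and no step can be read between compound 2 and compound 4. The compounds shown leave open what nitro in place of fluoro on the aromatic carbon does to the read-out.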